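Replacing the selenium-bearing group of compound 2

The source may report more compounds than this note shows. Statements on the series, on what has been measured and on what is new or still open speak of the compounds shown alone.

- compound 1 `CCOC(=O)c1cc([Se]c2ccc(F)cc2)c2cc(OC)ccc2n1`: > 150000 nM
- compound 2 `CCOC(=O)c1cc([Se]c2ccccc2)c2cc(OC)ccc2n1`: 33000 nM
- compound 3 `CCOC(=O)c1cc([Se]c2ccccc2)c2ccccc2n1`: 86300 nM

All three values come from a functional assay on SK-MEL-147 cells (Homo sapiens) for cytotoxicity, read by MTT assay, with a stated time of 24 h; a higher number here means that more compound is needed for the effect, a lower number that less compound is needed. Compound 1 gives > 150000 nM, which is a limit and not a number. Compound 2, at 33000 nM, holds the lower of the two actual numbers, and its nearest neighbour is compound 3 at 86300 nM.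

Next is compound 4 `CCOC(=O)c1cc(C#CCCO)c2cc(OC)ccc2n1`, which carries 4-hydroxybut-1-yn-1-yl on the shared core: a group of 5 heavy atoms (4 carbon, 1 oxygen; no ring) in place of a group of 7 heavy atoms (6 carbon, 1 selenium; one six-membered aromatic ring of carbon only), on an aromatic carbon.

Within the data shown here, two measured steps bear on this only indirectly. an at least 4.5-fold lower number from compound 1 to compound 2 (0.65 log units; beyond the scatter) concerns the group that leaves, and a 2.6-fold higher number from compound 2 to compound 3 (0.42 log units; beyond the scatter) concerns a methoxy group that compound 4 keeps. Neither step replaces the whole group, so their sizes are only a loose guide.

Compound 2 already has the lowest number at 33000 nM, so a modest rise in this assay is expected, with wide uncertainty. The expected step is a 1.8-fold higher number from compound 2 to compound 4 (0.26 log units; within the scatter). For compound 4 the estimated value is 60000 nM, with an expected range of 20000 nM to 150000 nM.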

Compound 4, half-maximal effective concentration: > 150000 nM
Compound 4 ended at the assay's limit; the forecaster's own chance of this, stated with the estimate: 25%; middle value at least 2.5-fold (0.39 log units) from the limit.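

Replacing the selenium-bearing group with 4-hydroxybut-1-yn-1-yl, on the aromatic carbon opposite the ring nitrogen, gives in this assay an at least 4.5-fold higher number from compound 2 to compound 4 (0.65 log units; beyond the scatter). The earlier steps shown here changed only a fluoro on the selenium-bearing group or a methoxy on the shared core, whereas this one exchanges the whole group and does not retain the number of compound 2. Compound 4 stands at a limit of this assay and not at a number: the limit of > 150000 nM in this assay, at which 2 of the 4 values shown sit.

The step between compound 1 and compound 4 cannot be read; selenium and the aromatic ring also leave together in compound 4, and nothing shown separates the two. On these data alone, whether a longer chain, or an amine or a carboxylic acid at the end of the chain, gives a readable number at this position remains open.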